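Hydroxyalkyl Group on the Pyrazole of an Antiproliferative Amide

The source may report more compounds than this note shows. Statements on the series, on what has been measured and on what is new or still open speak of the compounds shown alone.

Compound 1, `COc1cccc(CNC(=O)c2cccc(C(C)Oc3ccnc(Nc4cnn(C)c4)c3)c2)c1`, a limit: > 100000 nM
Compound 2, `COc1ccc(CNC(=O)c2cccc(C(C)Oc3ccnc(Nc4cnn(C)c4)c3)c2)cc1OC`: 38500 nM
Compound 3, `Cc1ccc(CNC(=O)c2cccc(C(C)Oc3ccnc(Nc4cnn(C)c4)c3)c2)cc1`: 7700 nM

In a functional assay on NCI-H3122 cells (Homo sapiens) for antiproliferative activity, read by MTT assay, with a stated time of 48 h (a lower number here means a stronger inhibitor, a higher number a weaker inhibitor), compound 3 gives the lowest number of the two numbers shown; the nearest is compound 2, and the step of a 5.0-fold lower number from compound 2 to compound 3 (0.70 log units; beyond the scatter) lies beyond the scatter. For compound 1 the result is only a limit of the assay, (the limit of > 100000 nM in this assay, at which 1 of the 3 values shown sits). The step of an at least 2.5-fold lower number from compound 1 to compound 2 (0.41 log units; beyond the scatter) and the step of an at least 12-fold lower number from compound 1 to compound 3 (1.11 log units; beyond the scatter) both rest on that limit.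

Compound 4, `Cc1ccc(CNC(=O)c2cccc(C(C)Oc3ccnc(Nc4cnn(CC(C)(C)O)c4)c3)c2)cc1`, differs from compound 3 by 1-hydroxy-1-methylethyl in place of hydrogen on a saturated chain carbon bound to an aromatic nitrogen. All three measured steps change the group on the saturated chain carbon bound to the amide-type nitrogen, on the other side of the shared core, so none of them bears on this change. The expectation is therefore a step within the scatter, a 1.5-fold lower number from compound 3 to compound 4 (0.19 log units; within the scatter). Compound 4 is estimated at 5000 nM, with a range from 1500 nM to 20000 nM.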

Compound 4, half-maximal inhibitory concentration: > 100000 nM
Compound 4 ended at the assay's limit; the forecaster's own chance of this, stated with the estimate: 5%; middle value at least 20-fold (1.30 log units) away from the limit.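

Within the data shown here, until compound 3, only the group on the saturated chain carbon bound to the amide-type nitrogen had varied, and compound 4 is the first to change the methyl to 2-hydroxy-2-methylpropyl. In this assay this single change gives an at least 12-fold higher number from compound 3 to compound 4 (1.11 log units; beyond the scatter), so this position is not silent: the change alone takes the compound with the lowest number shown to the end of the measurable range. The result for compound 4 is a limit of the assay, so the true size of the step stays unfixed: the limit of > 100000 nM in this assay, at which 2 of the 4 values shown sit.

The compounds shown do not separate the hydroxyl from the added carbons, which a plain 2-methylpropyl group at this place would address. Going by these compounds, how an amine or a carboxylic acid on such a chain would read also stays open.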